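The source may report more compounds than this note shows. Statements on the series, on what has been measured and on what is new or still open speak of the compounds shown alone.

Compound 1 `C=CCn1c(=O)/c(=C\c2cccc(F)c2)[nH]c(=O)/c1=C\c1ccccc1OC` gives 19700 nM in a functional assay on A549 cells (Homo sapiens) for cytotoxicity, read by CCK-8 assay, with a stated time of 72 h (a lower number here means a stronger inhibitor, a higher number a weaker inhibitor), the highest of the two numbers in hand. Compound 2 `C=CCn1c(=O)/c(=C\c2cccc(Cl)c2Cl)[nH]c(=O)/c1=C\c1ccccc1OC` gives 2300 nM in this assay, and the step of an 8.6-fold lower number from compound 1 to compound 2 (0.93 log units; beyond the scatter) is the only measured one in this series. Compound 3 `C=CCn1c(=O)/c(=C\c2cc(Br)ccc2F)[nH]c(=O)/c1=C\c1ccccc1OC` is reported in this assay as "not active" (no number reported), with no number attached. Compound 4 `C=CCn1c(=O)/c(=C\c2ccccc2C(F)(F)F)[nH]c(=O)/c1=C\c1ccccc1OC` differs from compound 1 by 2-(trifluoromethyl)phenyl in place of 3-fluorophenyl on a double-bonded chain carbon bound to an aromatic carbon. The step from compound 1 to compound 2 bears on this change and was modest, while compound 3 shows that another change at the same place can remove activity entirely. Among the compounds with values here, no measured step puts a trifluoromethyl group there, so the direction is uncertain. Compound 4 is therefore expected to land at 12000 nM, within 3000 nM to 50000 nM, a step of a 1.6-fold lower number from compound 1 to compound 4 (0.22 log units; within the scatter) that may not exceed the scatter.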

Compound 4, half-maximal inhibitory concentration: 7000 nM
Compound 4: middle estimate off by 1.7-fold (0.23 log units), on the high side; the measured number falls inside the stated range.
By their numbers in this assay, from the lowest: compound 2; then compound 4; then compound 1.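

In this assay this place on a double-bonded chain carbon bound to an aromatic carbon now has a second replacement of 3-fluorophenyl that lowers the number: 2-(trifluoromethyl)phenyl gives a 2.8-fold lower number from compound 1 to compound 4 (0.45 log units; beyond the scatter) and so falls on the same side of compound 1 as 2,3-dichlorophenyl. It does not match that group, as a 3.0-fold higher number from compound 2 to compound 4 (0.48 log units; beyond the scatter) shows. No evidence is available to explain this order.

Compound 3 goes against the lowering seen with the other two replacements, being reported as not active. The compounds shown leave open how a phenyl ring carrying an amine or a carboxylic acid would fare at this place.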